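Hydroxy to butoxy on the aromatic ring

The source may hold more compounds than are shown below. What is called first, only, known or untested is meant among the compounds shown, and "the series" means these compounds.

Of the compounds shown here, three have been measured so far in a functional assay on HL-60 cells (Homo sapiens) for cytotoxicity, read by WST assay, with a stated time of 48 h (a lower number here means that less compound is needed, a higher number that more compound is needed for the effect), and they span a modest range. Compound 3 (`Oc1ccccc1C[C@H]1COC[C@@H]1Cc1ccc(Cl)c(Cl)c1`) gives 34000 nM and holds the second highest of the three numbers. Compound 2 (`COc1ccccc1C[C@H]1COC(=O)[C@@H]1Cc1ccc(Cl)c(Cl)c1`) gives 14000 nM and lies lower, while compound 1 (`O=C1OC[C@H](Cc2ccccc2)[C@H]1Cc1ccc(O)cc1`) gives 88000 nM and lies higher, with each gap to compound 3 beyond the usual scatter.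

The next compound, compound 4 (`CCCCOc1ccccc1C[C@H]1COC[C@@H]1Cc1ccc(Cl)c(Cl)c1`), departs from compound 3 in one place, with butyl in place of hydrogen on an oxygen on an aromatic ring turning hydroxy into butoxy. For the measured compounds named here, no two measured compounds differ in one place only, so this kind of change has not been seen directly. The only hint is weak: compound 2, which also has no hydrogen on its oxygen on an aromatic ring, stands at 14000 nM against compound 3 at 34000 nM in this assay but the two differ elsewhere too. A modest step towards a lower number is therefore expected, somewhat beyond the scatter. The expected change is a 2.6-fold lower number from compound 3 to compound 4 (0.42 log units; beyond the scatter) as estimated here. For compound 4 the estimated value is 13000 nM (expected range 4000 nM to 40000 nM).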

Compound 4, half-maximal effective concentration: 20000 nM
Compound 4: the middle estimate sits 1.5-fold (0.19 log units) below what was measured, within the range that was stated.
By their numbers in this assay, from the lowest: compounds 2, 4 and 3 (each within the scatter of the next, the first and the last beyond it); then compound 1.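

In this assay, for the compounds shown here, putting butyl in place of hydrogen on the oxygen on an aromatic ring gives a 1.7-fold lower number from compound 3 to compound 4 (0.23 log units; within the scatter), the first step that can be read directly at one place. It shows that this oxygen can carry a butyl group, with 4 heavy atoms and no ring, without the number moving beyond the usual scatter, so removing the hydroxy hydrogen and adding this chain do not separate compound 3 and compound 4 in this assay. No measured property bears on this small step, so the result offers no explanation for it. The compounds shown leave open whether an ethoxy group, a longer chain such as hexyloxy, or an amine or carboxylic acid at the end of the chain would give a step beyond the scatter on the same core. They also leave open whether butoxy in place of hydroxy would give a similar step on the core of compound 2, which keeps a carbonyl that compound 3 and compound 4 lack.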